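Swapping an aromatic ring for a cyclopentenyl in thiazole acids

A few compounds are considered here, and "the series" means these few. Any claim that something is new, unique, unknown or untested is made for them only; others in the source may bear on it.

Of the compounds shown here, two have been measured in an assay on isolated protein for antagonist activity at prostaglandin E2 receptor EP1 subtype (Homo sapiens), read by reporter gene assay; a higher number here means a weaker inhibitor, a lower number a stronger inhibitor. Compound 1 `O=C(O)c1csc(-n2nc(-c3ccccc3)c3ccncc32)n1` gives 39 nM in this assay. Compound 2 `O=C(O)c1csc(-n2nc(-c3cccc(F)c3)c3ccccc32)n1` gives 20 nM in this assay. Compound 2 has the lower of the two numbers, but the gap to compound 1 is within the usual scatter of this assay, so the two cannot be told apart on these figures.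

Compound 3 `O=C(O)c1csc(-n2nc(C3=CCCC3)c3ccccc32)n1` has not yet been measured in this assay. It differs from compound 2 in one place: cyclopent-1-en-1-yl in place of 3-fluorophenyl on an aromatic carbon. Among the measured compounds shown here, no measured pair shows what this kind of change does in this assay, so there is no step to lean on. The expectation is a modest rise in the number from compound 2 to compound 3, a step of a 3.0-fold higher number from compound 2 to compound 3 (0.48 log units; beyond the scatter), which could still fall inside the scatter. On that basis compound 3 is estimated at 60 nM in this assay, with a likely range from 15 nM to 250 nM, anchored on compound 2 because its value of 20 nM is the closest starting point.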

Compound 3, half-maximal inhibitory concentration: 80 nM
Beside the measured number, compound 3's estimate is 1.3-fold (0.12 log units) below it; measured number inside the range.
By their numbers in this assay, from the lowest: compounds 2 and 1 (each within the scatter of the next); then compound 3.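

In this assay, the step from an aromatic ring to a non-aromatic one, with cyclopent-1-en-1-yl in place of 3-fluorophenyl, is a 4.0-fold higher number from compound 2 to compound 3 (0.60 log units; beyond the scatter). Among the compounds shown here, this is the first comparison here that changes one place only, and it shows that the group on this aromatic carbon does affect the number, since the step lies beyond the scatter. The step is still modest and compound 3 gives 80 nM, so an aromatic ring at this place is not needed for inhibition in the nanomolar range, though the 3-fluorophenyl group gives the lower number. No measurement shown here accounts for the size of this step.

The change alters several things at once: the ring size, the aromatic character and the presence of fluorine, so this single step cannot show which of them matters. A cyclopentyl ring, which lacks the double bond, or a cyclohexenyl ring, which keeps the double bond in a six-membered ring, would help to separate these features at this place on the same core.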